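Adding a Methoxy Group to Compound 2

The compounds below may be only part of what the source reports. "The series", "measured", "known", "first", "only" and "open" are said of these compounds alone.

Measured so far:
Compound 1, `CC1=CC[C@H](C(C)(C)N=C=S)CC1`: in a functional assay on 786-0 cells (Homo sapiens) for inhibition, read by sulforhodamine B assay, with a stated time of 48 h (a higher number here means a weaker inhibitor of growth, a lower number a stronger inhibitor of growth), compound 1 gives > 100000 nM, which is a limit of the assay and not a number.
Compound 2, `CC1=CC[C@H](C(C)(C)NC(=S)N/N=C/c2ccccc2)CC1`: in this assay compound 2 gives 67000 nM.

Going by the values given here, compound 2 stands alone with the only actual number among the two results. Among the compounds with values here, for compound 1 the assay reports only a limit (the limit of > 100000 nM in this assay, at which 1 of the 2 values shown sits), so no comparison between the two compounds can be drawn, and no step between measured compounds is available to lean on.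

Compound 3, `COc1ccc(/C=N/NC(=S)NC(C)(C)[C@H]2CC=C(C)CC2)cc1`, is the next compound to be measured. It differs from compound 2 in one place: methoxy in place of hydrogen on an aromatic carbon. Within the data shown here, nothing among the measured compounds shows what this change does in this assay, so the expectation rests on compound 2 at 67000 nM and on a change of modest size. The expected step in this assay is a 1.2-fold lower number from compound 2 to compound 3 (0.09 log units; within the scatter), small and without a clear direction, not beyond the usual scatter. Compound 3 is accordingly expected to give 55000 nM, with a range from 15000 nM to 150000 nM.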

Compound 3, concentration for total growth inhibition: 29600 nM
Estimate against measurement, compound 3: 1.9-fold (0.27 log units) above, and the stated range covers the measured number.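

Going from phenyl to 4-methoxyphenyl gives a 2.3-fold lower number from compound 2 to compound 3 (0.35 log units; beyond the scatter) in this assay, the first step that can be read in this series. It shows that growth inhibition in these cells responds to a change on the six-membered aromatic ring, at the carbon para to a large group, and that adding methoxy in place of hydrogen there moves the number toward stronger inhibition, if only modestly. Nothing at hand gives a reason for this step, so it stands as an observation about one pair of compounds and not as a trend.

Going by these compounds, it stays open whether this gain belongs to methoxy itself or would also come with other groups on the same carbon, such as a hydroxyl, a fluorine, a dimethylamino group or a longer chain like ethoxy. On these data alone, it is also open whether the same methoxy group would give a similar step on another carbon of the ring, or on a ring carrying a second group.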